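A few compounds are considered here, and "the series" means these few. Any claim that something is new, unique, unknown or untested is made for them only; others in the source may bear on it.

Measured so far in a physicochemical assay for lipophilicity, in phosphate buffer, measured as octanol-water partition; on this read-out lower numbers stand for lower lipophilicity and higher numbers for higher lipophilicity:
compound 1 `Cc1ccccc1NC(=S)NC(=O)Nc1ccc2c(c1)C(=O)C(=O)N2Cc1ccccc1` gives 2.98
compound 2 `Cc1cccc(NC(=S)NC(=O)Nc2ccc3c(c2)C(=O)C(=O)N3Cc2ccccc2)c1` gives 2.92
compound 3 `COc1ccccc1NC(=S)NC(=O)Nc1ccc2c(c1)C(=O)C(=O)N2Cc1ccccc1` gives 2.38

Compound 1 stands highest of the three; compound 2 comes nearest, with a number 0.06 log units lower from compound 1 to compound 2 (within the scatter), and compound 3 lies furthest, with a number 0.60 log units lower from compound 1 to compound 3 (beyond the scatter). Compound 4 `COc1ccc(NC(=S)NC(=O)Nc2ccc3c(c2)C(=O)C(=O)N3Cc2ccccc2)cc1` has not yet been measured. Its difference from compound 1 is 4-methoxyphenyl in place of 2-methylphenyl on an amide-type nitrogen. Two kinds of measured step bear on this. Exchanging methyl for methoxy gave a number 0.60 log units lower from compound 1 to compound 3 (beyond the scatter) and a number 0.54 log units lower from compound 2 to compound 3 (beyond the scatter), whereas shifting a methyl group around the ring gave only a number 0.06 log units lower from compound 1 to compound 2 (within the scatter). A modest drop in this assay is therefore expected, because a number 0.60 log units lower from compound 1 to compound 3 (beyond the scatter) sets the size, while the position of the group is expected to matter little. Compound 4 is estimated at 2.45, within 2.1 to 2.8, meaning an expected a number 0.53 log units lower from compound 1 to compound 4 (beyond the scatter).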

Compound 4, partition coefficient: 2.39
Compound 4: the middle estimate sits 0.06 log units above what was measured; the range from low to high includes it.
By their numbers in this assay, from the lowest: compounds 3 and 4 (each within the scatter of the next); then compounds 2 and 1 (each within the scatter of the next).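

In this assay, the 2-methoxyphenyl and 4-methoxyphenyl compounds cannot be told apart (a number 0.01 log units higher from compound 3 to compound 4 (within the scatter)), so moving methoxy around this ring, like moving methyl, shows no measurable change. Both methyl compounds stand apart from compound 4 (a number 0.59 log units lower from compound 1 to compound 4 (beyond the scatter); a number 0.53 log units lower from compound 2 to compound 4 (beyond the scatter)), so across these four compounds the number follows methyl versus methoxy, with none going against this. Nothing measured here gives a reason for that gap. Still open, from the compounds shown here alone, is how a phenyl ring carrying an amine or a carboxylic acid at this nitrogen would read, and whether 3-methoxyphenyl would sit with the other methoxy compounds.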